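One More Chain Carbon on Compound 2

The source may report more compounds than this note shows. Statements on the series, on what has been measured and on what is new or still open speak of the compounds shown alone.

Compound 1 (`CN(C)CCn1c(N)c(-c2nc3ccccc3n2C)c2nc(C#N)c(C#N)nc21`) gives > 50000 nM in a functional assay on K562 cells (Homo sapiens) for antiproliferative activity, read by MTT assay, with a stated time of 48 h (a lower number here means a stronger inhibitor, a higher number a weaker inhibitor), and this is a limit of the assay, not a number.

Among the compounds with values here, compound 2 (`CCN(CC)CCCn1c(N)c(-c2nc3ccccc3n2C)c2nc(C#N)c(C#N)nc21`) gives 3270 nM in this assay as the only true number so far, so it cannot yet be ranked against a second measured value.

Within the data shown here, the one measured step is an at least 15-fold lower number from compound 1 to compound 2 (1.18 log units; beyond the scatter) and it counts as large. That step put (diethylamino)methyl in place of dimethylamino, so the end group changed along with the chain.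

The next change, to compound 3 (`CCN(CC)CCCCn1c(N)c(-c2nc3ccccc3n2C)c2nc(C#N)c(C#N)nc21`), is (diethylamino)methyl in place of diethylamino on a saturated chain carbon, three bonds along the chain from an aromatic nitrogen and it leaves the diethylamino end as it was: 3-(diethylamino)propyl simply becomes 4-(diethylamino)butyl.

Among the measured compounds shown here, with only the step of an at least 15-fold lower number from compound 1 to compound 2 (1.18 log units; beyond the scatter) as a guide, and with one part of that change now absent, a much smaller move in the same direction is expected in this assay and it may be lost in the scatter.

The expected size is a 1.3-fold lower number from compound 2 to compound 3 (0.12 log units; within the scatter) as an estimate.

For compound 3 the estimated value is 2500 nM with an expected range from 800 nM to 8000 nM in this assay.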

Compound 3, half-maximal inhibitory concentration: 1010 nM
Compound 3: middle estimate off by 2.5-fold (0.39 log units), on the high side; measured number inside the range.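

With the diethylamino end held fixed, going from 3-(diethylamino)propyl to 4-(diethylamino)butyl gives a 3.2-fold lower number from compound 2 to compound 3 (0.51 log units; beyond the scatter), so in this assay the chain length alone moves the number, something the earlier pair could not show, as the end group changed there together with the chain. Compound 3 is now the strongest of the three in this small set, as its steps to both others lie beyond the scatter, though a single chain-only step does not yet make a trend. Across both changes the record reads an at least 49-fold lower number from compound 1 to compound 3 (1.69 log units; beyond the scatter), and this size is only a floor, since it starts from the value of compound 1, which is a limit and not a number: the limit of > 50000 nM in this assay, at which 1 of the 3 values shown sits.

From the compounds shown here alone, whether a longer chain, such as 5-(diethylamino)pentyl, would lower the number further or turn it back up stays open. Also open, going by these compounds, is what the end group contributes on its own, which a 3-(dimethylamino)propyl chain on the same core would separate from the effect of chain length.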